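The source may hold more compounds than are shown below. What is called first, only, known or untested is meant among the compounds shown, and "the series" means these compounds.

Measured so far:
- compound 1 `CC1CC/C(=N\Nc2ccccc2F)c2ncc(C(=O)O)c(=O)n21`: 5 umol/kg
- compound 2 `COc1ccc(N/N=C2\CCC(C)n3c2ncc(C(=O)O)c3=O)cc1`: 0.8 umol/kg

In a functional assay on the whole organism for inhibition, with Rattus norvegicus as the target (on this read-out lower numbers stand for an effect already at smaller amounts and higher numbers for an effect only at larger amounts of compound), compound 1 gives 5 umol/kg, while compound 2 gives 0.8 umol/kg. Among the compounds with values here, the only step measured in this assay, a 6.3-fold lower number from compound 1 to compound 2 (0.80 log units; beyond the scatter), follows the exchange of 2-fluorophenyl for 4-methoxyphenyl on the amine nitrogen. Within the data shown here, compound 2 thus stands at the lowest of the two numbers known, with compound 1 as its nearest neighbour.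

Compound 3 `Cc1cccc(N/N=C2\CCC(C)n3c2ncc(C(=O)O)c3=O)c1` is the next member of the series and has not been measured in this assay. Its change from compound 2 is 3-methylphenyl in place of 4-methoxyphenyl on an amine nitrogen. Among the measured compounds shown here, no measured step covers a methyl on the phenyl ring, nor the loss of a methoxy, so the step from compound 1 to compound 2 bears on it only indirectly: it shows that the substituent on this phenyl ring can move the number beyond the scatter. Since the 4-methoxyphenyl of compound 2 gave the lowest number, a return toward a somewhat higher number is expected for compound 3, of modest size, as a 2.5-fold higher number from compound 2 to compound 3 (0.40 log units; beyond the scatter). For compound 3 the estimate in this assay is 2 umol/kg, within 0.6 umol/kg to 6 umol/kg.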

Compound 3, dose for 50% inhibition: 0.4 umol/kg
Estimate against measurement, compound 3: 5.0-fold (0.70 log units) above, and the stated range ends above it.
By their numbers in this assay, from the lowest: compounds 3 and 2 (each within the scatter of the next); then compound 1.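

In this assay the exchange of 4-methoxyphenyl for 3-methylphenyl on the amine nitrogen gives a 2.0-fold lower number from compound 2 to compound 3 (0.30 log units; within the scatter) so the two groups cannot be told apart here, even though the entering group carries no hydrogen-bond acceptor and the leaving group carries one. A methoxy oxygen is thus not needed on this phenyl ring for a number at this level, and the exchange of 2-fluorophenyl for 3-methylphenyl, with a 13-fold lower number from compound 1 to compound 3 (1.10 log units; beyond the scatter) shows that compound 1 stands clear of compound 3 by more than the step to compound 2 had shown. No measurement at hand offers an explanation for these differences.

Group and ring location change together in all three compounds, so it remains open whether the gap to compound 1 follows from the fluorine itself or from where it sits on the phenyl ring. Also open, from the compounds shown here alone, is how far this position tolerates other groups, such as an unsubstituted phenyl, a chlorophenyl, a pyridine ring or a phenyl bearing a carboxylic acid.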